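This account rests on a few compounds, and the source may have more. Where it says the series, first, only, none or still open, it means among the compounds named here.

Compound 1 `O=C(CNC(=O)c1cc(Cl)ccc1O)Nc1cccc(Cl)c1` was measured in a functional assay on K562 cells (Homo sapiens) for cytotoxicity, with a stated time of 72 h; on this read-out higher numbers stand for weaker inhibition and lower numbers for stronger inhibition. In this assay compound 1 gives > 10000 nM, which is a limit of the assay and not a number. Compound 2 `C[C@H](NC(=O)c1cc(Cl)ccc1O)C(=O)Nc1cccc(Cl)c1` was measured in the same way. In this assay compound 2 gives > 10000 nM, again a limit rather than a number.

Among the compounds with values here, compound 2 therefore stands at the limit, and the limit of > 10000 nM in this assay, at which 2 of the 2 values shown sit, shows that every value so far sits there. Within the data shown here, the one step between measured compounds, a step that the two limits leave unreadable from compound 1 to compound 2, cannot be read because both ends are limits. Compound 3 `Cc1ccc(NC(=O)[C@H](C)NC(=O)c2cc(Cl)ccc2O)cc1` differs from compound 2 by 4-methylphenyl in place of 3-chlorophenyl on an amide-type nitrogen. Among the measured compounds shown here, no measured step touches this part of the molecule, and the single measured step gives no size at all, so for compound 3 the expected step is a step that the limit leaves unreadable from compound 2 to compound 3, with a further limit the most likely outcome. The estimate for compound 3 is 15000 nM, with a range from 4000 nM to 60000 nM.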

Compound 3, half-maximal inhibitory concentration: > 10000 nM
Compound 3 gave a limit, no number; the forecaster's own chance of this, stated with the estimate: 85%; the middle value lies beyond the limit too.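

In this assay compound 3 gives > 10000 nM, a limit and not a number, so no new step can be read between compound 2 and compound 3. The compounds shown leave open whether either change has any effect, with every value at one point: the limit of > 10000 nM in this assay, at which 3 of the 3 values shown sit.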